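The compounds below may be only part of what the source reports. "The series", "measured", "known", "first", "only" and "open" are said of these compounds alone.

Measured compounds:
compound 1 `Cc1ccc(C(=O)NN(C(=O)c2ccccc2Cl)C(C)(C)C)cc1C` — 87.1 nM
compound 2 `CCOc1ccccc1C(=O)N(NC(=O)c1ccc(CC)cc1)C(C)(C)C` — 2880 nM

In an assay on cells for agonist activity at ecdysone receptor (Bombyx mori), read by a luciferase reporter, with a stated time of 24 h (a lower number here means that less compound is needed, a higher number that more compound is needed for the effect), compound 2 gives the higher of the two numbers shown; compound 1 gives a lower number, and the gap between them lies beyond the scatter. For the measured compounds named here, no pair differing in one place has been measured, so nothing anchors the next step.

Compound 3 `CCCCCCC(=O)N(NC(=O)c1ccc(CC)cc1)C(C)(C)C` is the next entry: hexyl in place of 2-ethoxyphenyl on a carbonyl carbon. Going by the values given here, with no measured step of this kind, the size of the move is uncertain; the expected direction is toward a higher number, and the expected step from compound 2 to compound 3 is a 2.8-fold higher number from compound 2 to compound 3 (0.44 log units; beyond the scatter). Compound 3 is estimated at 8000 nM in this assay, with a range from 1500 nM to 40000 nM.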

Compound 3, half-maximal effective concentration: 11700 nM
Estimate against measurement, compound 3: 1.5-fold (0.17 log units) below, and the stated range covers the measured number.
By their numbers in this assay, from the lowest: compound 1; then compound 2; then compound 3.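

Hexyl in place of 2-ethoxyphenyl on a carbonyl carbon gives a 4.1-fold higher number from compound 2 to compound 3 (0.61 log units; beyond the scatter) in this assay and provides the first single-place step in the series. At this position, the aromatic ring can give way to an open chain with a loss beyond the scatter, while a measurable number remains. No measured evidence bears on the reason for this step. Still open, as far as these compounds go, is whether a butyl or octyl chain would move the number from that of compound 3. A cyclohexyl or unsubstituted phenyl group would help separate the effect of the ring from that of the ethoxy group.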